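A dichlorophenyl swap among closely matched amides

The source may report more compounds than this note shows. Statements on the series, on what has been measured and on what is new or still open speak of the compounds shown alone.

Compound 1 `O=C(O)CC(NC(=O)c1ccc(Cl)cc1Cl)c1ccccc1`: 67200 nM
Compound 2 `CC(C)(C)c1ccc(C(CC(=O)O)NC(=O)c2ccc(F)cc2)cc1`: 87600 nM
Compound 3 `CC(C)(C)c1ccc(C(CC(=O)O)NC(=O)c2ccc(C(F)(F)F)cc2)cc1`: 78800 nM

In a functional assay on MDA-MB-231 cells (Homo sapiens) for antiproliferative activity, read by MTT assay, with a stated time of 24 h (a lower number here means a stronger inhibitor, a higher number a weaker inhibitor), compound 2 gives 87600 nM, which lies within the scatter of both other measured compounds, so the three numbers do not separate. The step followed here leads to compound 4 `CC(C)(C)c1ccc(C(CC(=O)O)NC(=O)c2c(Cl)cccc2Cl)cc1`: 2,6-dichlorophenyl in place of 4-fluorophenyl on a carbonyl carbon. In words, 2,6-dichlorophenyl comes in place of 4-fluorophenyl on a carbonyl carbon.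

One measured step changes this same aromatic group on an otherwise unchanged structure: a 1.1-fold lower number from compound 2 to compound 3 (0.05 log units; within the scatter). Compound 1 also carries chlorine on this aromatic group, although the rest of its structure differs, and compound 1 gives 67200 nM, again within the scatter of compound 2. For the measured compounds named here, no measured compound carries the 2,6-dichlorophenyl group itself, so the range has to stay wide. Given the small size of these differences, no step beyond the scatter is expected in this assay. The expected change is a 1.2-fold lower number from compound 2 to compound 4 (0.07 log units; within the scatter). For compound 4 the estimated value is 75000 nM, with an expected range from 35000 nM to 160000 nM.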

Compound 4, half-maximal inhibitory concentration: > 100000 nM
Compound 4: no number, only a limit; the forecaster's own chance of this, stated with the estimate: 15%; at least 1.3-fold (0.12 log units) between middle value and limit.
By their numbers in this assay, from the lowest: compounds 1, 3 and 2 (each within the scatter of the next). At a limit, above all of these: compound 4.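

Compound 4 gives > 100000 nM in this assay and that is a limit, not a number. The change from 4-fluorophenyl to 2,6-dichlorophenyl on a carbonyl carbon therefore reads only as an at least 1.1-fold higher number from compound 2 to compound 4 (0.05 log units; that floor lies within the scatter) and so, alone among the changes shown at this position, it yields a limit rather than a value, while its floor does not separate it from the earlier numbers. The result rests on a single reading at that limit: the limit of > 100000 nM in this assay, at which 1 of the 4 values shown sits.

As far as these compounds go, how far the value of compound 4 lies past its limit stays open, so the size of this step remains unknown. Whether a 4-chlorophenyl or a 4-aminophenyl group on this carbonyl carbon would give a number that separates from the others cannot be told from the compounds shown.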